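From 2-hydroxyphenyl to pyridin-3-yl: one untested change

The source may hold more compounds than are shown below. What is called first, only, known or untested is meant among the compounds shown, and "the series" means these compounds.

Of the compounds shown here, two have numbers so far. In a functional assay on MGC-803 cells (Homo sapiens) for antiproliferative activity, read by CellTiter-Glo, with a stated time of 72 h (a higher number here means a weaker inhibitor, a lower number a stronger inhibitor), compound 2 (`O=C(NO)c1ccc(/C=C/c2ccnc(-c3ccccc3O)c2)cc1`) gives 1420 nM and compound 1 (`O=C(NO)c1cccc(/C=C/c2ccnc(-c3cc(F)ccc3O)c2)c1`) gives 2710 nM as its value. These two values lie within the scatter of each other, so the numbers do not separate the pair.

Compound 3 (`O=C(NO)c1ccc(/C=C/c2ccnc(-c3cccnc3)c2)cc1`) has not yet been measured. It differs from compound 2 in one place, with pyridin-3-yl in place of 2-hydroxyphenyl on an aromatic carbon. For the measured compounds named here, no two measured compounds differ in only one place, so the data hold no direct precedent for this change and give no sign of which way it should move the number. The expectation therefore starts from compound 2 at 1420 nM as the closest reference. No shift beyond the scatter is expected in this assay and the estimated 1.1-fold higher number from compound 2 to compound 3 (0.02 log units; within the scatter) carries no firm direction. Compound 3 is expected at 1500 nM with a wide estimated range (500 nM to 4500 nM).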

Compound 3, half-maximal inhibitory concentration: 4550 nM
Estimate against measurement, compound 3: 3.0-fold (0.48 log units) below; the measured number lies above the stated range.
By their numbers in this assay, from the lowest: compounds 2, 1 and 3 (each within the scatter of the next, the first and the last beyond it).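

In this assay, for the compounds shown here, replacing 2-hydroxyphenyl with pyridin-3-yl gives a 3.2-fold higher number from compound 2 to compound 3 (0.51 log units; beyond the scatter), the only one-place step available here and one that lies beyond the scatter, so this place on the shared core does respond to the group it carries, at least for this pair. The change alters both the atoms of the ring and the hydroxyl: the hydrogen-bond donor count falls from 1 to 0 while the hydrogen-bond acceptor count stays at 1, and this single step cannot separate the loss of the hydroxyl from the arrival of the ring nitrogen. No measurement accompanying these compounds bears on why the number rises, so the step stands only as an observation.

The compounds shown leave open whether a plain phenyl, a 2-methoxyphenyl or a 2-aminophenyl at this place would stay close to compound 2 or move towards compound 3, which would help to show whether the hydroxyl or the ring nitrogen matters more. They also leave open whether the same exchange would have a similar effect on the core of compound 1.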